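Phenyl in place of 1H-indol-4-yl: expected step

The source may hold more compounds than are shown below. What is called first, only, known or untested is meant among the compounds shown, and "the series" means these compounds.

In a physicochemical assay for lipophilicity, at pH 7.4 (on this read-out lower numbers stand for lower lipophilicity and higher numbers for higher lipophilicity), compound 1 `CNC(=O)c1cc(C(=O)N[C@H]2[C@@H]3COC[C@@H]32)cc2c1OC[C@H]2c1cccnc1` gives 1.4, compound 2 `CNC(=O)c1cc(C(=O)N[C@H]2[C@@H]3COC[C@@H]32)cc2c1OC[C@H]2c1cccc(OC)c1` gives 3.2 and compound 3 `CNC(=O)c1cc(C(=O)N[C@H]2[C@@H]3COC[C@@H]32)cc2c1OC[C@H]2c1cccc2[nH]ccc12` gives 3.1. Compound 3 cannot be told apart from compound 2 and lies well above compound 1.

Compound 4 `CNC(=O)c1cc(C(=O)N[C@H]2[C@@H]3COC[C@@H]32)cc2c1OC[C@H]2c1ccccc1` carries phenyl in place of 1H-indol-4-yl on a saturated ring carbon.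

All three measured steps concern this same carbon. The two that leave pyridin-3-yl are large: a number 1.80 log units higher from compound 1 to compound 2 (beyond the scatter) and a number 1.70 log units higher from compound 1 to compound 3 (beyond the scatter). The exchange of 3-methoxyphenyl for 1H-indol-4-yl gives only a number 0.10 log units lower from compound 2 to compound 3 (within the scatter). Phenyl has a six-membered aromatic ring of carbon only, as do the groups of compound 2 and compound 3, so the nearest guide is a number 0.10 log units lower from compound 2 to compound 3 (within the scatter). For the measured compounds named here, no step of phenyl itself has been measured, and no step beyond the scatter is expected in this assay. The expected change is a number 0.10 log units lower from compound 3 to compound 4 (within the scatter). Compound 4 is estimated at 3, with an expected range of 2.6 to 3.4.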

Compound 4, distribution coefficient: 3.3
Beside the measured number, compound 4's estimate is 0.30 log units below it, within the range that was stated.
By their numbers in this assay, from the lowest: compound 1; then compounds 3, 2 and 4 (each within the scatter of the next).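

In this assay, removing the fused five-membered ring or the methoxy group leaves the number unresolved from those of the larger groups, with a number 0.20 log units higher from compound 3 to compound 4 (within the scatter) and a number 0.10 log units higher from compound 2 to compound 4 (within the scatter) both read at this saturated ring carbon. Of the four groups at this carbon, only pyridin-3-yl stands apart, with a number 1.90 log units higher from compound 1 to compound 4 (beyond the scatter) showing that plain phenyl alone is enough to give the large step from compound 1. Nothing at hand accounts for these steps.

Still open, on these data alone, is whether pyridin-2-yl or pyridin-4-yl would track pyridin-3-yl in this assay or phenyl instead. Also open, as far as these compounds go, is where a carboxylic acid or an aminomethyl group on the phenyl ring of compound 4 would fall in this assay relative to compound 1 and compound 4.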